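A larger group on the aromatic nitrogen of compound 2

The source may report more compounds than this note shows. Statements on the series, on what has been measured and on what is new or still open speak of the compounds shown alone.

Measured in a physicochemical assay for lipophilicity, using the shake flask method, measured as octanol-water partition, at pH 7.4; a lower number here means a more polar compound, a higher number a more lipophilic compound:
Compound 1 `CC(C)Cn1cc(-c2ccnc3[nH]c(C4CCN(CC(=O)N(C)C)CC4)cc23)ccc1=O`: 2
Compound 2 `CC(C)n1cc(-c2ccnc3[nH]c(C4CCN(CC(=O)N(C)C)CC4)cc23)ccc1=O`: 1.9

Compound 2, at 1.9, lies within the scatter of compound 1. Compound 3 `CN(C)C(=O)CN1CCC(c2cc3c(-c4ccc(=O)n(CCC5CCOCC5)c4)ccnc3[nH]2)CC1` has not been measured yet. It carries 2-(oxan-4-yl)ethyl in place of isopropyl on an aromatic nitrogen. For the measured compounds named here, only one measured step touches a group on that nitrogen, a number 0.10 log units lower from compound 1 to compound 2 (within the scatter), and it stays within the scatter. This swap is much larger, so that single step guides the expectation only loosely. No shift beyond the scatter is expected, and the estimated step is a number 0.20 log units higher from compound 2 to compound 3 (within the scatter). For compound 3 the estimated value is 2.1, with an expected range from 1.7 to 2.5.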

Compound 3, distribution coefficient: 1.5
Compound 3: middle estimate off by 0.60 log units, on the high side, outside the stated range (below it).
By their numbers in this assay, from the lowest: compound 3; then compounds 2 and 1 (each within the scatter of the next).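

In this assay, the group on the aromatic nitrogen can move the number beyond the scatter: 2-(oxan-4-yl)ethyl in place of isopropyl gives a number 0.40 log units lower from compound 2 to compound 3 (beyond the scatter), and the same group against isobutyl gives a number 0.50 log units lower from compound 1 to compound 3 (beyond the scatter). Here, the larger group, with more carbon atoms and a ring, carries the lower number, so size alone does not set the direction. No measurement shown explains this shift. Going by these compounds, whether the ring oxygen matters remains open. A 2-cyclohexylethyl group, with carbon in place of that oxygen, would separate its contribution from that of the ring and chain.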